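A Methoxy Group on a Barely Active Compound

The compounds below may be only part of what the source reports. "The series", "measured", "known", "first", "only" and "open" are said of these compounds alone.

In a functional assay on KB cells (Homo sapiens) for inhibition, read by MTT assay, with a stated time of 24 h, tested at 10 ug/mL (a lower number here means less inhibition of growth, a higher number more inhibition of growth at the concentration tested), compound 1 `O=C(CCCCC(S)CCS)Nc1ccccc1` gives 8.62%. Compound 3 `O=C(CCCCC(S)CCS)Nc1cccc(C(F)(F)F)c1` gives 1.97%, within the scatter of compound 1, so neither can be ranked over the other. Compound 2 `O=C(CCCCC(S)CCS)Nc1ccccc1Cl` is reported as "not active" (no number reported), with no number. Compound 4 `COc1ccc(NC(=O)CCCCC(S)CCS)cc1` differs from compound 1 by methoxy in place of hydrogen on an aromatic carbon, which is methoxy in place of hydrogen on an aromatic carbon. Among the measured compounds shown here, the one measured step of a similar kind is a number 6.7 percentage points lower from compound 1 to compound 3 (within the scatter), with trifluoromethyl in place of hydrogen on an aromatic carbon. One small step is thin evidence, but it gives no reason to expect a change beyond the scatter. The estimated step is a number 2.6 percentage points lower from compound 1 to compound 4 (within the scatter). Compound 4 is expected to give 6%, with an estimated range from 0% to 16%.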

Compound 4, percent growth inhibition at one concentration: 8.93%
Estimate against measurement, compound 4: 2.9 percentage points below; the measured number falls inside the stated range.
By their numbers in this assay, from the lowest: compounds 3, 1 and 4 (each within the scatter of the next).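

In this assay, a number 0.3 percentage points higher from compound 1 to compound 4 (within the scatter), so the two readings cannot be told apart. Methoxy on this aromatic carbon, para to a large group, thus joins trifluoromethyl as a second replacement of hydrogen whose step stays within the scatter, this time with a group holding an oxygen atom. As far as these compounds go, whether an amine or a carboxylic acid on this same carbon, or a longer chain ending in an oxygen atom, would move the reading beyond the scatter stays open. Nothing shown here offers an explanation for this result.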